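Pyridin-3-yl for pyridin-2-yl on the hydrazone carbon

The compounds below may be only part of what the source reports. "The series", "measured", "known", "first", "only" and "open" are said of these compounds alone.

Compound 1, `C/C(=N\Nc1nc2ccccc2o1)c1ccccn1`, has the lowest number of the two measured compounds in a functional assay on HeLa cells (Homo sapiens) for antiproliferative activity, read by sulforhodamine B assay (on this read-out higher numbers stand for weaker inhibition and lower numbers for stronger inhibition), where compound 1 gives 23 nM. For the measured compounds named here, its nearest neighbour is compound 2, `CCC/C(=N\Nc1nc2ccccc2o1)c1ccccn1`, which in this assay gives 153 nM; that pair is the only measured step, a 6.7-fold higher number from compound 1 to compound 2 (0.82 log units; beyond the scatter), and it concerns the saturated chain carbon, not the aromatic ring.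

Compound 3, `C/C(=N\Nc1nc2ccccc2o1)c1cccnc1`, is not yet measured. It differs from compound 1 in one place: pyridin-3-yl in place of pyridin-2-yl on a carbon with a double bond to nitrogen. Going by the values given here, no measured step touches this ring, so the chain step between compound 1 and compound 2 gives no direct guide to the size or direction of this change; it only shows that single-point changes can move the number beyond the scatter.

Among the compounds with values here, with no direct precedent, the expectation for compound 3 is a weaker number than compound 1, with a wide range: compound 3 is expected at 300 nM, between 50 nM and 3000 nM. This estimate means a step of a 13-fold higher number from compound 1 to compound 3 (1.12 log units; beyond the scatter).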

Compound 3, half-maximal inhibitory concentration: > 100000 nM
Compound 3 ended at the assay's limit; the forecaster's own chance of this, stated with the estimate: 10%; middle value at least 330-fold (2.52 log units) away from the limit.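

In this assay compound 3 gives > 100000 nM, which is a limit of the assay and not a number: the limit of > 100000 nM in this assay, at which 1 of the 3 values shown sits.

The two compounds have the same atoms, and the computed counts for the two rings are identical, yet pyridin-3-yl in place of pyridin-2-yl on a carbon with a double bond to nitrogen gives an at least 4300-fold higher number from compound 1 to compound 3 (3.63 log units; beyond the scatter). For the compounds shown here, this ring change therefore moves the read-out much further than the only earlier step, the chain change, which gave a 6.7-fold higher number from compound 1 to compound 2 (0.82 log units; beyond the scatter), so pyridin-2-yl at this place is the feature of compound 1 that the series so far shows to be most sensitive to change.

The compounds shown do not establish whether the loss is specific to pyridin-3-yl, as neither pyridin-4-yl nor phenyl on this carbon appears among them to show whether either stays near the 23 nM of compound 1. They also give no reason for the size of the step, and they do not show how this ring change would behave on the longer chain of compound 2.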